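A Fluorophenyl Swap Followed in a Cytotoxicity Assay

The source may report more compounds than this note shows. Statements on the series, on what has been measured and on what is new or still open speak of the compounds shown alone.

Compound 1 `COc1cc2c(Oc3ccc(NC(=O)c4nn(-c5ccccc5F)c(=O)c5ccccc45)cc3F)ccnc2cc1OCCCN1CCCC1` — 400 nM
Compound 2 `COc1cc2c(Oc3ccc(NC(=O)c4nn(-c5cccc(F)c5)c(=O)c5ccccc45)cc3F)ccnc2cc1OCCCN1CCC(C)CC1` — 500 nM

In a functional assay on HT-29 cells (Homo sapiens) for cytotoxicity, read by MTT assay, with a stated time of 72 h (a lower number here means a stronger inhibitor, a higher number a weaker inhibitor), compound 1 gives 400 nM, while compound 2 gives 500 nM. Compound 2 stands highest of the two numbers, yet its gap to compound 1 lies within the scatter, so no order between them can be read. Compound 3 `COc1cc2c(Oc3ccc(NC(=O)c4nn(-c5ccccc5F)c(=O)c5ccccc45)cc3F)ccnc2cc1OCCCN1CCC(C)CC1` differs from compound 2 by 2-fluorophenyl in place of 3-fluorophenyl on an aromatic nitrogen. For the measured compounds named here, no measured pair shows this change alone. Compound 1 carries the same 2-fluorophenyl and gives 400 nM, close to compound 2, so the writer expects a 1.1-fold lower number from compound 2 to compound 3 (0.05 log units; within the scatter), no step beyond the scatter. Compound 3 is estimated at 450 nM, between 200 nM and 1000 nM.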

Compound 3, half-maximal inhibitory concentration: 510 nM
Beside the measured number, compound 3's estimate is 1.1-fold (0.05 log units) below it; the measured number falls inside the stated range.
By their numbers in this assay, from the lowest: compounds 1, 2 and 3 (each within the scatter of the next).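

In this assay, 2-fluorophenyl in place of 3-fluorophenyl on an aromatic nitrogen, now seen alone, gives a 1.0-fold higher number from compound 2 to compound 3 (0.01 log units; within the scatter), so the two fluorophenyl groups cannot be told apart at this position. Likewise, 4-methylpiperidin-1-yl in place of pyrrolidin-1-yl, also seen alone, gives a 1.3-fold higher number from compound 1 to compound 3 (0.11 log units; within the scatter). No other data here bear on these results. The compounds shown leave open whether 4-fluorophenyl or plain phenyl on that nitrogen would read differently. They also leave open whether a morpholine at the chain end would do so.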